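This account rests on a few compounds, and the source may have more. Where it says the series, first, only, none or still open, it means among the compounds named here.

In a functional assay on PC-3 cells (Homo sapiens) for cytotoxicity, read by MTT assay, with a stated time of 72 h (on this read-out higher numbers stand for weaker inhibition and lower numbers for stronger inhibition), compound 1 `CNC(=O)c1cc(Oc2ccc(C3=NNC(c4ccc(Cl)cc4Cl)C3)cc2)ccn1` gives 7300 nM and compound 3 `CNC(=O)c1cc(Oc2ccc(C3=NNC(c4ccc(OC)cc4)C3)cc2)ccn1` gives 7740 nM, so these two stand within the scatter of each other. Compound 2 `CNC(=O)c1cc(Oc2ccc(C3=NNC(c4ccc([N+](=O)[O-])cc4)C3)cc2)ccn1` gives > 50000 nM, which is a limit of the assay and not a number. Compound 4 `CNC(=O)c1cc(Oc2ccc(C3=NNC(c4ccccc4)C3)cc2)ccn1` carries phenyl in place of 2,4-dichlorophenyl on a saturated ring carbon. Two measured changes at this same place bear on it: a 1.1-fold higher number from compound 1 to compound 3 (0.03 log units; within the scatter), while an at least 6.8-fold higher number from compound 1 to compound 2 (0.83 log units; beyond the scatter). Compound 4 has no nitro group, so the first of these is taken as the guide, and no step beyond the scatter is expected in this assay. The expected step is a 1.2-fold higher number from compound 1 to compound 4 (0.09 log units; within the scatter). For compound 4 the estimated value is 9000 nM, with an expected range of 3500 nM to 25000 nM.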

Compound 4, half-maximal inhibitory concentration: 4520 nM
Compound 4: the middle estimate sits 2.0-fold (0.30 log units) above what was measured, and the stated range covers the measured number.
By their numbers in this assay, from the lowest: compounds 4, 1 and 3 (each within the scatter of the next). At a limit, above all of these: compound 2.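

In this assay, plain phenyl at this saturated ring carbon stands level with both substituted aryl groups: a 1.6-fold lower number from compound 1 to compound 4 (0.21 log units; within the scatter), and a 1.7-fold lower number from compound 3 to compound 4 (0.23 log units; within the scatter), so neither the two chlorines nor the methoxy is required here. Only the nitro group goes against this, with an at least 11-fold lower number from compound 2 to compound 4 (1.04 log units; beyond the scatter). Compound 2 stands at a limit and not at a number: the limit of > 50000 nM in this assay, at which 1 of the 4 values shown sits.

Going by these compounds, whether an amine or a carboxylic acid on the phenyl ring would track with methoxy or with nitro remains open. Also open, on these data alone, is whether any group at this position can take the number clearly below that of compound 4.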